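Dimethylamino for Methoxy: Expected Effect on Growth Inhibition

The compounds below may be only part of what the source reports. "The series", "measured", "known", "first", "only" and "open" are said of these compounds alone.

Compound 1 `CC1=CC[C@H](C(C)(C)NC(=S)N/N=C/c2ccccc2)CC1` — in a functional assay on UACC-62 cells (Homo sapiens) for inhibition, read by sulforhodamine B assay, with a stated time of 48 h (a lower number here means a stronger inhibitor of growth, a higher number a weaker inhibitor of growth), compound 1 gives > 100000 nM, which is a limit of the assay and not a number.
Compound 2 `COc1ccc(/C=N/NC(=S)NC(C)(C)[C@H]2CC=C(C)CC2)cc1` — in this assay compound 2 gives 70400 nM.
Compound 3 `CC1=CC[C@H](C(C)(C)NC(=S)N/N=C/c2ccccc2O)CC1` — in this assay compound 3 gives 10800 nM.

Among the two plain numbers, compound 2 has the higher one; compound 3 sits well below it, as the step of a 6.5-fold lower number from compound 2 to compound 3 (0.81 log units; beyond the scatter) shows, and compound 1 is known only as a limit (the limit of > 100000 nM in this assay, at which 1 of the 3 values shown sits).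

Compound 4 `CC1=CC[C@H](C(C)(C)NC(=S)N/N=C/c2ccc(N(C)C)cc2)CC1` differs from compound 2 by dimethylamino in place of methoxy on an aromatic carbon. Among the compounds with values here, no measured step exchanges one group for another at the same aromatic carbon. The nearest guides are the steps of an at least 1.4-fold lower number from compound 1 to compound 2 (0.15 log units; that floor lies within the scatter), which stays within the scatter, and an at least 9.2-fold lower number from compound 1 to compound 3 (0.96 log units; beyond the scatter), which is at least modest but concerns a different group at a different position. A modest step in this assay is therefore not excluded, but no clear direction follows from the shown compounds. For compound 4 the estimate in this assay is 50000 nM, within 15000 nM to 150000 nM. This estimate implies a step of a 1.4-fold lower number from compound 2 to compound 4 (0.15 log units; within the scatter) that is expected to stay within the scatter.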

Compound 4, concentration for total growth inhibition: > 100000 nM
Compound 4: no number, only a limit (the forecaster's own chance of this, stated with the estimate: 30%); at least 2.0-fold (0.30 log units) between middle value and limit.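

Within the data shown here, the exchange of methoxy for dimethylamino on an aromatic carbon, para to a large group, is the first direct swap of one group for another at this place, and in this assay it gives an at least 1.4-fold higher number from compound 2 to compound 4 (0.15 log units; that floor lies within the scatter). Compound 4 gives > 100000 nM, which is a limit of the assay and not a number, so dimethylamino here yields no readable value. The step from compound 1 to compound 4 cannot be read, since both compounds rest on the same limit: the limit of > 100000 nM in this assay, at which 2 of the 4 values shown sit.

On these data alone, how far compound 4 lies past its limit stays open, and with it the true size of this change. Also open, as far as these compounds go, is whether a plain amino group or a carboxylic acid on this same aromatic carbon would give a readable value.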